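A Phenyl in Place of Methyl: Expected Cytotoxicity

The compounds below may be only part of what the source reports. "The series", "measured", "known", "first", "only" and "open" are said of these compounds alone.

In a toxicity assay on THP-1 cells (Homo sapiens) for cytotoxicity, read by MTT assay (a higher number here means a weaker inhibitor of growth, a lower number a stronger inhibitor of growth), compound 1, with the structure `C/C(=N\Nc1nc(-c2ccc(F)cc2)cs1)c1sc(C)nc1C`, gives > 100 ug/mL, which is a limit of the assay rather than a measured number. Compound 2, with the structure `C/C(=N\Nc1nc(-c2ccc(Br)cc2)cs1)c1sc(C)nc1C`, gives > 100 ug/mL, again only a limit. Compound 3, with the structure `COc1ccc(-c2csc(N/N=C(\C)c3sc(C)nc3C)n2)cc1`, gives > 100 ug/mL, also a limit. These three compounds differ only in the group on the outer aromatic ring, and the steps between them, a step that the two limits leave unreadable from compound 1 to compound 2, a step that the two limits leave unreadable from compound 1 to compound 3 and a step that the two limits leave unreadable from compound 2 to compound 3, cannot be read because of the limit of > 100 ug/mL in this assay, at which 3 of the 3 values shown sit.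

Compound 4, with the structure `C/C(=N\Nc1nc(-c2ccc(F)cc2)cs1)c1sc(-c2ccccc2)nc1C`, has not yet been measured. Its change from compound 1 is phenyl in place of methyl on an aromatic carbon. Among the measured compounds shown here, none of the measured steps touch this position, and all three sit at the limit, so they give no read on the size of the step. The expected step is therefore a number no higher from compound 1 to compound 4 (the limit leaves the size open), which is taken to lie within the scatter. Compound 4 is estimated at 100 ug/mL in this assay, with a range from 40 ug/mL to 250 ug/mL.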

Compound 4, concentration for 50% growth inhibition: > 100 ug/mL
Compound 4 gave a limit, no number; the forecaster's own chance of this, stated with the estimate: 65%; the middle value lies on the limit itself.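

The step between compound 1 and compound 4 cannot be read, because both compounds give a limit of the assay rather than a number: the limit of > 100 ug/mL in this assay, at which 4 of the 4 values shown sit.

As far as these compounds go, whether phenyl in place of methyl changes growth inhibition in this assay at all, and by how much, stays open.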